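Cyano for Hydroxy on the Benzyl Ether of Compound 2

The source may report more compounds than this note shows. Statements on the series, on what has been measured and on what is new or still open speak of the compounds shown alone.

Measured compounds:
compound 1 `CS(=O)(=O)c1nn2cc(-c3cc4ccccc4o3)nc2s1`: 820 nM
compound 2 `COc1cc(OCc2cccc(O)c2)c2cc(-c3cn4nc(OC)sc4n3)oc2c1`: 3.1 nM
compound 3 `Cc1nn2cc(-c3cc4ccccc4o3)nc2s1`: 37 nM

Three compounds have numbers in a functional assay on HEK293 cells for antagonist activity at proteinase-activated receptor 4 (Homo sapiens), read by FLIPR and calcium flux, with a stated time of 30 min; a lower number here means a stronger inhibitor, a higher number a weaker inhibitor. Among them compound 2 stands lowest; the nearest of the others is compound 3, and the furthest is compound 1, both gaps lying beyond the scatter of the assay. Within the data shown here, the single step between measured compounds that differ in one place is a 22-fold lower number from compound 1 to compound 3 (1.35 log units; beyond the scatter), a change on the shared core and not on the benzyl ether.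

Compound 4 `COc1cc(OCc2cccc(C#N)c2)c2cc(-c3cn4nc(OC)sc4n3)oc2c1` differs from compound 2 by cyano in place of hydroxy on an aromatic carbon. Among the measured compounds shown here, no measured pair touches this part of the molecule. For the measured compounds named here, the one known step, from compound 1 to compound 3, concerns a different substituent on a different ring, so it offers no direction for the present change and cannot be read as a guide for it. With nothing in the data pointing one way or the other, the expectation is a small move at most, in either direction.

Compound 4 is therefore estimated at 5 nM, with a range from 1.5 nM to 20 nM, and the step this estimate implies is expected to be a 1.6-fold higher number from compound 2 to compound 4 (0.21 log units; within the scatter).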

Compound 4, half-maximal inhibitory concentration: 0.98 nM
For compound 4 the middle estimate is 5.1-fold (0.71 log units) above the measured one, outside the stated range (below it).
By their numbers in this assay, from the lowest: compound 4; then compound 2; then compound 3; then compound 1.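

In this assay, this position on the benzyl ether now has a measured step of its own, a 3.2-fold lower number from compound 2 to compound 4 (0.50 log units; beyond the scatter), for cyano in place of hydroxy on an aromatic carbon, meta to a large group. The hydroxy carries a hydrogen-bond donor and the cyano carries none, yet the number falls beyond the scatter, so for this pair a donor at this place is not needed for a low number. No measurement among the compounds shown accounts for why the number falls with this change.

From the compounds shown here alone, the two compounds give a single comparison at this position, so it remains open whether the lower number belongs to the cyano in particular or would also appear with another group here, such as an amine, a carboxylic acid, a methoxy or a longer chain. Going by these compounds, it also remains open whether the same change would give a step of similar size with a substituent other than methoxy on the shared core of compound 2 and compound 4.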